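The compounds below may be only part of what the source reports. "The series", "measured", "known", "first", "only" and "open" are said of these compounds alone.

Three compounds have been measured in a functional assay on HepG2 cells (Homo sapiens) for antiproliferative activity, read by MTT assay, with a stated time of 24 h; on this read-out higher numbers stand for weaker inhibition and lower numbers for stronger inhibition:

Compound 1 `O=c1[nH]cc(S(=O)(=O)Nc2ccccc2-c2cn(-c3ccccc3F)nn2)c(=O)[nH]1`: 12500 nM
Compound 2 `O=c1[nH]cc(S(=O)(=O)Nc2ccccc2-c2cn(-c3cccc(Cl)c3)nn2)c(=O)[nH]1`: 2460 nM
Compound 3 `O=c1[nH]cc(S(=O)(=O)Nc2cccc(-c3cn(-c4ccccc4)nn3)c2)c(=O)[nH]1`: 11200 nM

Compound 3 stands second highest of these three numbers; compound 1 lies within the scatter of it, while compound 2 lies well below it. Compound 4 `O=c1[nH]cc(S(=O)(=O)Nc2cccc(-c3cn(-c4ccc(Cl)cc4)nn3)c2)c(=O)[nH]1` differs from compound 3 by chloro in place of hydrogen on an aromatic carbon. For the measured compounds named here, the only measured step that bears on this change is a 5.1-fold lower number from compound 1 to compound 2 (0.71 log units; beyond the scatter), a modest one, though there the group that left was fluoro rather than hydrogen and the chlorophenyl that entered was a 3-chlorophenyl rather than a 4-chlorophenyl. On that basis a lowering of similar or somewhat smaller size is expected for compound 4, a 2.2-fold lower number from compound 3 to compound 4 (0.35 log units; beyond the scatter). Compound 4 is therefore estimated at 5000 nM, with a range from 1500 nM to 15000 nM.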

Compound 4, half-maximal inhibitory concentration: 1960 nM
Estimate against measurement, compound 4: 2.6-fold (0.41 log units) above, and the stated range covers the measured number.
By their numbers in this assay, from the lowest: compounds 4 and 2 (each within the scatter of the next); then compounds 3 and 1 (each within the scatter of the next).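

In this assay, chloro in place of hydrogen gives a 5.7-fold lower number from compound 3 to compound 4 (0.76 log units; beyond the scatter) with nothing else in the structure changed, whereas the earlier chlorophenyl step also removed a fluoro. A single chlorine on this aromatic carbon, para to a large group, is therefore enough by itself to move the number beyond the scatter. No measurement here explains why the number falls.

As far as these compounds go, whether a methoxy group, an amine or a carboxylic acid on the same carbon would also lower the number remains open. So does whether bromo would match chloro there.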